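This account rests on a few compounds, and the source may have more. Where it says the series, first, only, none or still open, it means among the compounds named here.

Working notes on the series in an in vitro ADME assay on microsomes from liver (Mus musculus) for pharmacokinetics, read by LC-MS, with a stated time of 10 min, tested at 1 uM; a lower number here means slower removal, a higher number faster removal of the compound: compound 1 (`CN1C[C@H](C(=O)Nc2ccc(C3CC3)cc2)[C@@H](c2ccc(/C=C/C(=O)Nc3ccccc3N)cc2)C1`) gives 60 mL/min/kg, and compound 2 (`CN1C[C@H](C(=O)Nc2ccccc2F)[C@@H](c2ccc(/C=C/C(=O)Nc3ccccc3N)cc2)C1`) gives 67 mL/min/kg. On these two numbers, compound 2 stands level with compound 1, within the scatter.

Next is compound 3 (`Cc1cc(NC(=O)[C@H]2CN(C)C[C@@H]2c2ccc(/C=C/C(=O)Nc3ccccc3N)cc2)ccc1F`), which has 4-fluoro-3-methylphenyl in place of 2-fluorophenyl on an amide-type nitrogen. Going by the values given here, one measured step bears on this change, as it falls at the same place: a 1.1-fold higher number from compound 1 to compound 2 (0.05 log units; within the scatter). That exchange of 4-cyclopropylphenyl for 2-fluorophenyl stayed within the scatter. Among the compounds with values here, it is a single step, however, and no measured compound carries 4-fluoro-3-methylphenyl.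

No shift beyond the scatter is therefore expected in this assay, the estimated change being a 1.1-fold lower number from compound 2 to compound 3 (0.05 log units; within the scatter). The estimate for compound 3 is 60 mL/min/kg, with an expected range of 35 mL/min/kg to 100 mL/min/kg.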

Compound 3, clearance: 62 mL/min/kg
The estimate for compound 3 lay 1.0-fold (0.01 log units) below the measured number, within the range that was stated.
By their numbers in this assay, from the lowest: compounds 1, 3 and 2 (each within the scatter of the next).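

Compared with the single earlier step, this position now has three different aryl groups on the amide-type nitrogen in this assay, and the new group stays within the scatter against both earlier ones: (a 1.1-fold lower number from compound 2 to compound 3 (0.03 log units; within the scatter)) and (a 1.0-fold higher number from compound 1 to compound 3 (0.01 log units; within the scatter)). Across compounds 1, 2 and 3, the exchange of one fluorinated or cyclopropyl-bearing phenyl group for another therefore leaves the clearance level, with no compound going against this, and the added methyl of 4-fluoro-3-methylphenyl brings no step beyond the scatter. No supporting measurement is available to explain this level read-out.

The compounds shown leave open whether a phenyl group carrying a carboxylic acid or an amine would stay level too. They also leave open what a straight alkyl chain in place of the phenyl group would do, and whether changes elsewhere on the shared core would move the clearance.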